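Stereocentre inversion in a set of limit-only compounds

The compounds below may be only part of what the source reports. "The series", "measured", "known", "first", "only" and "open" are said of these compounds alone.

The series holds compound 1 `CCCCSc1nsnc1C1CN2CCC[C@@H]1C2`, compound 2 `CCCCSc1nsnc1[C@H]1CN2CCC[C@H]1C2` and compound 3 `CCCCSc1nsnc1[C@@H]1CN2CCC[C@@H]1C2`. In a functional assay on the whole organism for inhibition, with Rattus norvegicus as the target (on this read-out higher numbers stand for an effect only at larger amounts of compound and lower numbers for an effect already at smaller amounts), compound 1 gives only a limit, > 3 mg/kg. Compound 2 likewise sits at a limit in this assay, > 3 mg/kg. Compound 3 also stands at a limit, > 3 mg/kg, so its place on the numbers shown is not fixed. All three values are limits (the limit of > 3 mg/kg in this assay, at which 3 of the 3 values shown sit), and the steps a step that the two limits leave unreadable from compound 1 to compound 2, a step that the two limits leave unreadable from compound 1 to compound 3 and a step that the two limits leave unreadable from compound 2 to compound 3 stay unreadable. Compound 4 `CCCCSc1nsnc1[C@@H]1CN2CCC[C@H]1C2` differs from compound 3 only in configuration: the two compounds have the same atoms and bonds; at least one stereo element is drawn with a configuration in one of them and without one in the other: 1 of 3 stereo elements differ; a stereocentre at a saturated ring carbon is drawn S in compound 3 and R in compound 4. Going by the values given here, the steps that bear on this change, all between stereoisomers, give no readable size, so no direction beyond the scatter is expected and a further limit seems most likely. Compound 4 is estimated at 5 mg/kg, within 1.5 mg/kg to 30 mg/kg, meaning an expected step that the limit leaves unreadable from compound 3 to compound 4.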

Compound 4, dose for half-maximal effect: 0.018 mg/kg
Beside the measured number, compound 4's estimate is 280-fold (2.44 log units) above it, and the stated range ends above it.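

In this assay, configuration alone now separates compounds with the same atoms and bonds: inverting one saturated ring carbon from S to R gives an at least 160-fold lower number from compound 3 to compound 4 (2.22 log units; beyond the scatter). The other single-centre change, from R to S at a saturated ring carbon, gives an at least 160-fold lower number from compound 2 to compound 4 (2.22 log units; beyond the scatter), and the change at two stereo elements gives an at least 160-fold lower number from compound 1 to compound 4 (2.22 log units; beyond the scatter). Of the four stereo forms shown, only the one drawn in compound 4 has a measured number, and the steps among the other three cannot be read.

Going by these compounds, how far compounds 1, 2 and 3 lie past their limits stays open, so each step has only a minimum size. Also open, on these data alone, is whether the configuration of compound 4 keeps this effect with a longer chain, such as hexyl, in place of butyl.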